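This account rests on a few compounds, and the source may have more. Where it says the series, first, only, none or still open, it means among the compounds named here.

Compound 1 `CCN(CC)Cc1ccc2nc(NC(=O)N/N=C/c3cn(Cc4ccc(C(C)(C)C)cc4)c4ccccc34)sc2c1` gives 1710 nM in a functional assay on A549 cells (Homo sapiens) for cytotoxicity, read by MTT assay, with a stated time of 72 h (on this read-out lower numbers stand for stronger inhibition and higher numbers for weaker inhibition), the second highest of the three numbers in hand. Compound 3 `CCN(CC)Cc1ccc2nc(NC(=O)N/N=C/c3cn(Cc4ccccc4Cl)c4ccccc34)sc2c1` lies nearest with 1390 nM, and compound 2 `CCN(CC)Cc1ccc2nc(NC(=O)N/N=C/c3cn(Cc4ccccc4)c4ccccc34)sc2c1` furthest with 3330 nM; the steps of a 1.2-fold lower number from compound 1 to compound 3 (0.09 log units; within the scatter) and a 1.9-fold higher number from compound 1 to compound 2 (0.29 log units; within the scatter) both stay within the scatter, while a 2.4-fold lower number from compound 2 to compound 3 (0.38 log units; beyond the scatter) is a modest step beyond it. Compound 4 `CC1CCN(Cc2ccc3nc(NC(=O)N/N=C/c4cn(Cc5ccc(C(C)(C)C)cc5)c5ccccc45)sc3c2)CC1` differs from compound 1 by 4-methylpiperidin-1-yl in place of diethylamino on a saturated chain carbon bound to an aromatic carbon. Within the data shown here, all three measured steps alter the group on a saturated chain carbon bound to an aromatic nitrogen; none touches the diethylamino side of the core, so no measured step bears directly on this change. The expectation is therefore no step beyond the scatter, a 1.0-fold lower number from compound 1 to compound 4 (0.00 log units; within the scatter). Compound 4 is estimated at 1700 nM, with a range of 600 nM to 5000 nM.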

Compound 4, half-maximal inhibitory concentration: 3710 nM
Beside the measured number, compound 4's estimate is 2.2-fold (0.34 log units) below it; the measured number falls inside the stated range.
By their numbers in this assay, from the lowest: compounds 3, 1, 2 and 4 (each within the scatter of the next, the first and the last beyond it).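

The diethylamino side of the core is not silent in this assay: 4-methylpiperidin-1-yl in place of diethylamino gives a 2.2-fold higher number from compound 1 to compound 4 (0.34 log units; beyond the scatter), a modest step. The series now shows a step beyond the scatter at the saturated chain carbon bound to an aromatic carbon, not only at the group on the aromatic nitrogen. No evidence is available to account for this step.

Still open, as far as these compounds go, is whether the ring or its methyl carries the step; unsubstituted piperidin-1-yl or morpholin-4-yl would help separate them. Also open, from the compounds shown here alone, is whether the step holds with the 2-chlorophenyl group of compound 3.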